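Methyl in Place of Methoxy on a Serotonin Receptor Ligand

The source may report more compounds than this note shows. Statements on the series, on what has been measured and on what is new or still open speak of the compounds shown alone.

Going by the values given here, compound 1 `COc1ccc(S(=O)(=O)c2n[nH]c3cc(N4CCNCC4)ccc23)cc1` is one of two compounds measured in an assay on HeLa cells for displacement of a labelled ligand from 5-hydroxytryptamine receptor 6 (Homo sapiens) (a higher number here means a weaker inhibitor, a lower number a stronger inhibitor), where compound 1 gives 124 nM. Compound 2 `CCCn1nc(S(=O)(=O)c2cccc3ccccc23)c2cc(N3CCNCC3)ccc21` gives 2.2 nM in this assay, so compound 1 carries the higher of the two numbers, and the gap between them lies beyond the usual scatter. These two compounds differ in more than one place, so nothing in the data ties any single change to that gap.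

Compound 3 `Cc1ccc(S(=O)(=O)c2n[nH]c3cc(N4CCNCC4)ccc23)cc1` keeps the core of compound 1 and alters one group: methyl in place of methoxy on an aromatic carbon. Among the compounds with values here, no measured pair shows this change, so there is no step of the same kind to lean on.

The expectation for compound 3 is a small step in this assay, most likely within the scatter and without a confident direction. The estimated step of a 1.2-fold higher number from compound 1 to compound 3 (0.08 log units; within the scatter) is expected to stay modest. Compound 3 is therefore estimated at 150 nM in this assay, with a range from 50 nM to 450 nM.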

Compound 3, inhibition constant: 27 nM
Estimate against measurement, compound 3: 5.6-fold (0.74 log units) above; measured number below the stated range.
By their numbers in this assay, from the lowest: compound 2; then compound 3; then compound 1.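

In this assay, going by these compounds alone, the change from 4-methoxyphenyl to 4-methylphenyl gives a 4.6-fold lower number from compound 1 to compound 3 (0.66 log units; beyond the scatter) and is the first step in the set that can be tied to one place, showing that the group on this ring, para to a large group, is not indifferent to binding. Methyl carries no hydrogen-bond acceptor, where methoxy carries one, so an acceptor at this place is not required for the number to fall on this core. Nothing shown gives a measured reason for the direction or size of this step.

The compounds shown leave open how other groups would fare at this place, such as a chlorine atom, an ethyl group or an amine. The gap to compound 2 also stays unassigned, since that compound differs from compound 3 in more than one place.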